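The compounds below may be only part of what the source reports. "The series", "measured", "known", "first", "only" and "open" are said of these compounds alone.

Measured so far:
Compound 1 `CCOC(=O)/C=C/c1cnc(Nc2ccc(C#N)cc2)nc1Oc1c(C)cc(C#N)cc1C` — in an ADME assay on TZM cells (Homo sapiens) for cytotoxicity, with a stated time of 1 days (on this read-out lower numbers stand for higher toxicity in this test and higher numbers for lower toxicity in this test), compound 1 gives > 227 nM, which is a limit of the assay and not a number.
Compound 2 `Cc1cc(C#N)cc(C)c1Oc1nc(Nc2ccc(C#N)cc2)ncc1/C=C/C(=O)NC1CCN(S(C)(=O)=O)C1` — in this assay compound 2 gives > 179 nM, again a limit rather than a number.

For the measured compounds named here, compound 2 therefore stands only at a limit in this assay, and the one other value shown is a limit as well. Going by the values given here, the single measured step, a step that the two limits leave unreadable from compound 1 to compound 2, cannot be read, since both ends sit at limits (the limit of > 227 nM in this assay, at which 1 of the 2 values shown sits, and (the limit of > 179 nM in this assay, at which 1 of the 2 values shown sits)).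

The next compound, compound 3 `CC(=O)N1CCN(C(=O)/C=C/c2cnc(Nc3ccc(C#N)cc3)nc2Oc2c(C)cc(C#N)cc2C)CC1`, has not yet been tested in this assay. The change from compound 2 is 4-acetylpiperazin-1-yl in place of (1-(methylsulfonyl)pyrrolidin-3-yl)amino on a carbonyl carbon. Among the compounds with values here, only the step from compound 1 to compound 2 bears on this kind of change at the carbonyl carbon, and its size is not readable. Nothing in the two values shown points to toxicity within the tested range, so a further limit is the most likely outcome.

Compound 3 is expected to show no step beyond the scatter, an estimated step that the limit leaves unreadable from compound 2 to compound 3. For compound 3 the estimate in this assay is 300 nM, with a range from 150 nM to 1000 nM.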

Compound 3, half-maximal cytotoxic concentration: > 192 nM
Compound 3 gave a limit, no number; the forecaster's own chance of this, stated with the estimate: 80%; the middle value is on the limit's open side.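

In this assay compound 3 gives > 192 nM, which is a limit of the assay and not a number. For the compounds shown here, with compound 1 and compound 2 also at limits, no step among the three can be read. The compounds shown leave open at what concentration any of them turns cytotoxic, and whether the group on the carbonyl carbon changes that concentration.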